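Inserting a methylene between the nitrogen and the bicyclic ring

A few compounds are considered here, and "the series" means these few. Any claim that something is new, unique, unknown or untested is made for them only; others in the source may bear on it.

Three compounds share one core. Compound 1 `Cn1c(=O)c(S(=O)(=O)c2ccc(F)cc2F)cc2cnc(Nc3ccc4cc[nH]c4c3)nc21`, compound 2 `O=c1c(S(=O)(=O)c2ccc(F)cc2F)cc2cnc(Nc3ccc4[nH]ccc4c3)nc2n1C1CC1` and compound 3 `Cn1c(=O)c(S(=O)(=O)c2ccc(F)cc2F)cc2cnc(Nc3ccc4sccc4c3)nc21` were tested in a functional assay on K562 cells (Homo sapiens) for inhibition, read by trypan blue exclusion, with a stated time of 72 h; a higher number here means a weaker inhibitor, a lower number a stronger inhibitor. Compound 1 gives 5000 nM, compound 2 gives 500 nM and compound 3 gives 500 nM. Among the compounds with values here, compound 3 therefore sits level with compound 2, and both stand well apart from compound 1; the only single-change step seen, a 10-fold lower number from compound 1 to compound 3 (1.00 log units; beyond the scatter), spans that gap. Compound 4 `Cn1c(=O)c(S(=O)(=O)c2ccc(F)cc2F)cc2cnc(NCc3ccc4[nH]ccc4c3)nc21` differs from compound 3 by one change, ((1H-indol-5-yl)methyl in place of 1-benzothiophen-5-yl on a nitrogen on an aromatic ring). No measured step covers this change; the one step shown swaps one bicyclic ring for another on the nitrogen itself, so it bears only loosely. A weaker number is expected, roughly a 4.0-fold higher number from compound 3 to compound 4 (0.60 log units; beyond the scatter). Compound 4 is thus estimated at 2000 nM, with a range from 400 nM to 10000 nM.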

Compound 4, half-maximal inhibitory concentration: 75000 nM
The estimate for compound 4 lay 38-fold (1.57 log units) below the measured number; measured number outside the range, above it.
By their numbers in this assay, from the lowest: compounds 2 and 3 (each within the scatter of the next); then compound 1; then compound 4.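

In this assay, (1H-indol-5-yl)methyl on this nitrogen costs more than the earlier ring swap did: a 150-fold higher number from compound 3 to compound 4 (2.18 log units; beyond the scatter), and a 15-fold higher number from compound 1 to compound 4 (1.18 log units; beyond the scatter). Both steps are large, so a ring attached through a methylene fares worse here than either ring attached directly to the nitrogen in compound 1 and compound 3. Nothing shown accounts for this loss. From the compounds shown here alone, compound 4 changes both the attachment and the ring, so the share of each remains open. (1-Benzothiophen-5-yl)methyl on the same nitrogen would separate them, and a longer chain would test whether added length costs more.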